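The compounds below may be only part of what the source reports. "The series", "measured", "known", "first", "only" and "open" are said of these compounds alone.

Of the compounds shown here, three built on one shared core have been tested in an assay on mitochondria from L6 cells (Rattus norvegicus) for activation, with a stated time of 90 min; a lower number here means that less compound is needed, a higher number that more compound is needed for the effect. Compound 1 `Oc1nc2nonc2nc1Nc1ccc(OCC(F)(F)F)cc1` gives 42300 nM, compound 2 `Oc1nc2nonc2nc1Nc1ccc(S(F)(F)(F)(F)F)cc1` gives 3900 nM, and compound 3 `Oc1nc2nonc2nc1Nc1ccccc1`, which carries only hydrogen at the varied position, gives 66700 nM. Compound 3 thus holds the highest number of the three: the gap to it is a 1.6-fold higher number from compound 1 to compound 3 (0.20 log units; within the scatter) and a 17-fold higher number from compound 2 to compound 3 (1.23 log units; beyond the scatter), so only the second of these counts as a real difference.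

Compound 4 `CCCCCc1ccc(Nc2nc3nonc3nc2O)cc1` differs from compound 3 by pentyl in place of hydrogen on an aromatic carbon. Two measured steps speak to such a change at this position. The step of a 17-fold higher number from compound 2 to compound 3 (1.23 log units; beyond the scatter) shows that removing a substituent there can raise the number greatly, whereas a 1.6-fold higher number from compound 1 to compound 3 (0.20 log units; within the scatter) shows that another substituent made no real difference. Adding the pentyl group is therefore expected to lower the number, though by an amount that is hard to pin down. In this assay compound 4 is estimated to give 12000 nM, within a range of 2500 nM to 50000 nM, which would amount to an expected 5.6-fold lower number from compound 3 to compound 4 (0.74 log units; beyond the scatter).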

Compound 4, half-maximal effective concentration: 2400 nM
Estimate against measurement, compound 4: 5.0-fold (0.70 log units) above, and the stated range ends above it.
By their numbers in this assay, from the lowest: compounds 4 and 2 (each within the scatter of the next); then compounds 1 and 3 (each within the scatter of the next).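

In this assay pentyl in place of hydrogen brings a 28-fold lower number from compound 3 to compound 4 (1.44 log units; beyond the scatter), so a low number at this position does not depend on the group of compound 2, and a chain of carbon alone can also produce it. The pentyl chain and the fluorine- and sulfur-containing group stand level, with a 1.6-fold lower number from compound 2 to compound 4 (0.21 log units; within the scatter) between them. Group size, counted in heavy atoms, does not settle the outcome either, since 2,2,2-trifluoroethoxy is of similar size to pentyl, yet the change to pentyl gives an 18-fold lower number from compound 1 to compound 4 (1.25 log units; beyond the scatter). Nothing at hand explains why these groups differ.

The compounds shown leave open how the number follows chain length, which a propyl or an octyl chain would test. They also leave open whether a pentyl chain tolerates a carboxylic acid or an amine at its end.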